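Notes on a hydroxamic acid series: amide-nitrogen and carbonyl substituents

A few compounds are considered here, and "the series" means these few. Any claim that something is new, unique, unknown or untested is made for them only; others in the source may bear on it.

Measured compounds:
compound 1 `O=C(/C=C/c1ccccc1)N[C@@H](CCCCCC(=O)NO)C(=O)NCc1ccccc1` 4010 nM
compound 2 `O=C(/C=C/c1ccccc1)N[C@@H](CCCCCC(=O)NO)C(=O)Nc1cccc2cccnc12` 1240 nM

Of the compounds shown here, two have been tested in a functional assay on NFF cells (Homo sapiens) for antiproliferative activity; on this read-out lower numbers stand for stronger inhibition and higher numbers for weaker inhibition. Within the data shown here, compound 2 holds the lowest number of the two; the only neighbour is compound 1, and the step of a 3.2-fold lower number from compound 1 to compound 2 (0.51 log units; beyond the scatter) came with quinolin-8-yl in place of benzyl on an amide-type nitrogen.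

Compound 3 `CC(C)COC(=O)N[C@@H](CCCCCC(=O)NO)C(=O)Nc1cccc2cccnc12` keeps the quinolin-8-yl amide of compound 2 and differs only at the carbonyl carbon whose other neighbour is the amide-type nitrogen: isobutoxy in place of 2-phenylethenyl on a carbonyl carbon

Among the measured compounds shown here, no measured step touches this position; the single step in hand concerns the amide-nitrogen substituent and gives no guide to exchanging 2-phenylethenyl for isobutoxy. The expectation is therefore anchored on compound 2 with wide bounds. For compound 3 the estimated step is a 1.6-fold higher number from compound 2 to compound 3 (0.21 log units; within the scatter), with the number expected near 2000 nM and a range from 600 nM to 7000 nM.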

Compound 3, half-maximal inhibitory concentration: 81 nM
Compound 3: middle estimate off by 25-fold (1.39 log units), on the high side; the whole stated range lies above it.
By their numbers in this assay, from the lowest: compound 3; then compound 2; then compound 1.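

In this assay the carbonyl carbon on the amide-type nitrogen proves a highly sensitive position: isobutoxy in place of 2-phenylethenyl gives a 15-fold lower number from compound 2 to compound 3 (1.18 log units; beyond the scatter), a large step against the modest one at the amide nitrogen (a 3.2-fold lower number from compound 1 to compound 2 (0.51 log units; beyond the scatter)). With the quinolin-8-yl amide held constant, the six-membered aromatic ring and the double bond of 2-phenylethenyl are not needed for the lowest number in the series, which belongs to compound 3 with its ring-free isobutoxy group. No supporting data bear on why this exchange has such an effect.

The compounds shown do not separate the oxygen of isobutoxy from its branched carbon chain, a question that an isopentyl group or a benzyloxy group on the same carbonyl carbon would address. As far as these compounds go, whether the gain carries over to the benzyl amide of compound 1 also remains open.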